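Benzyl piperazine swap on a shared core: cytotoxicity

The source may report more compounds than this note shows. Statements on the series, on what has been measured and on what is new or still open speak of the compounds shown alone.

Compound 1 `CCOC(=O)c1cnc(N2CCN(Cc3ccc(C(=O)OC)cc3)CC2)nc1Oc1c(C)cc(-c2ccc(C#N)cc2)cc1C`: in an ADME assay on MT4 cells (Homo sapiens) for cytotoxicity, read by MTT assay, with a stated time of 4 days (on this read-out higher numbers stand for lower toxicity in this test and lower numbers for higher toxicity in this test), compound 1 gives > 125000 nM, a limit of the assay.
Compound 2 `CCOC(=O)c1cnc(N2CCN(Cc3cccc([N+](=O)[O-])c3)CC2)nc1Oc1c(C)cc(-c2ccc(C#N)cc2)cc1C`: in this assay compound 2 gives > 125000 nM, again a limit.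

Compound 2 thus stands only at a limit in this assay, and the other value shown sits at the same limit (the limit of > 125000 nM in this assay, at which 2 of the 2 values shown sit). The step that the two limits leave unreadable from compound 1 to compound 2 is not readable; both of its ends are limits. The change 4-carbamoylphenyl in place of 3-nitrophenyl on a saturated chain carbon bound to an amine nitrogen in a ring gives compound 3 `CCOC(=O)c1cnc(N2CCN(Cc3ccc(C(N)=O)cc3)CC2)nc1Oc1c(C)cc(-c2ccc(C#N)cc2)cc1C`. Among the compounds with values here, the one measured step bears on it only as two limits, so no step beyond the scatter is expected in this assay, and the expected step is a number no higher from compound 2 to compound 3 (the limit leaves the size open). Compound 3 is estimated at 125000 nM, within 60000 nM to 300000 nM.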

Compound 3, half-maximal cytotoxic concentration: 66500 nM
Compound 3: middle estimate off by 1.9-fold (0.27 log units), on the high side; low and high end bracket the measured number.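

At the group on a saturated chain carbon bound to an amine nitrogen in a ring, compound 3 is the only one of the three compounds with a number rather than a limit in this assay: the limit of > 125000 nM in this assay, at which 2 of the 3 values shown sit.

Replacing 3-nitrophenyl with 4-carbamoylphenyl gives an at least 1.8-fold lower number from compound 2 to compound 3 (0.27 log units; that floor lies within the scatter), and amino in place of methoxy on the carbonyl carbon gives an at least 1.8-fold lower number from compound 1 to compound 3 (0.27 log units; that floor lies within the scatter). Going by these compounds, both steps are floors, so their true sizes stay unknown, but they show that a change at this position can yield a readable number.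

The compounds shown leave open whether a carboxylic acid or an amine in place of the carbamoyl group would give a number or stay at the limit.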